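Chloro on the shared core: following compound 2 to compound 4

The compounds below may be only part of what the source reports. "The series", "measured", "known", "first", "only" and "open" are said of these compounds alone.

Measured so far:
compound 1, `Cc1ccc(S(=O)(=O)NC(=O)n2ccc3cccnc32)cc1`: 20.3%
compound 2, `O=C(NS(=O)(=O)c1ccc2ccccc2c1)n1ccc2cccnc21`: 1.9%
compound 3, `O=C(NS(=O)(=O)c1ccc2ccccc2c1)n1ccc2cc(Br)cnc21`: 28.8%

Three compounds share a core and were tested in a functional assay on MCF7 cells (Homo sapiens) for antiproliferative activity, read by MTT assay, with a stated time of 24 h, tested at 10 uM; a lower number here means less inhibition, a higher number more inhibition at the concentration tested (going by the name of the read-out). Compound 2 gives 1.9% in this assay and stands lowest of the three numbers; compound 1 is its nearest neighbour, and compound 3 the furthest, with both steps beyond the scatter.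

Compound 4, `O=C(NS(=O)(=O)c1ccc2ccccc2c1)n1ccc2c(Cl)ccnc21`, differs from compound 2 in one place: chloro in place of hydrogen on an aromatic carbon. Among the measured compounds shown here, only one measured step speaks to a halogen entering on an aromatic carbon of this core: a number 26.9 percentage points higher from compound 2 to compound 3 (beyond the scatter). That step brought a modest rise beyond the scatter. In compound 4 a halogen also enters, though the group and the place are not the same as in compound 3, so the rise is expected to be smaller and less certain.

The expected step is a number 13.1 percentage points higher from compound 2 to compound 4 (beyond the scatter). Compound 4 is therefore estimated to give 15% in this assay, within a range from 0% to 35%.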

Compound 4, a percentage reported as inhibition, at one concentration (the size of the read-out at that concentration, not a potency): 28.6%
Estimate against measurement, compound 4: 13.6 percentage points below, within the range that was stated.
By their numbers in this assay, from the lowest: compound 2; then compounds 1, 4 and 3 (each within the scatter of the next).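

In this assay, chloro on an aromatic carbon opposite the ring nitrogen gives a number 26.7 percentage points higher from compound 2 to compound 4 (beyond the scatter) and so shows that this position of the six-membered aromatic ring can take a halogen with a clear rise in inhibition. Alongside a number 26.9 percentage points higher from compound 2 to compound 3 (beyond the scatter) for a bromo group, this gives two upward halogen steps from compound 2, so among these compounds the rise is not confined to one halogen at one place. No measurement here explains the rise.

The compounds shown carry only halogens on the core, so it remains open whether an amine, a methoxy group or a carboxylic acid at this position would also raise the number. From the compounds shown here alone, it is also open whether chloro here would do the same on compound 1, which has a different group on the sulfonyl.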